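From compound 2 to compound 4: one aryl group changes

A few compounds are considered here, and "the series" means these few. Any claim that something is new, unique, unknown or untested is made for them only; others in the source may bear on it.

compound 1 `COc1ccc(C2=C(c3cc(OC)c(OC)c(OC)c3)CC3CCCN3C2=O)cc1O`: > 100000 nM (a limit)
compound 2 `CSc1ccc(C2=C(c3ccc(F)c(C)c3)C(=O)N3CCCC3C2)cc1`: 500 nM
compound 3 `COc1ccc(C2=C(c3ccc(SC)cc3)CC3CCCN3C2=O)cc1OC`: 600 nM

All values come from a functional assay on MCF-A cells (Homo sapiens) for cytotoxicity; on this read-out higher numbers stand for weaker inhibition of growth and lower numbers for stronger inhibition of growth. Going by the values given here, compound 2 stands within the scatter of compound 3, the only other compound with an exact number. Compound 1 reaches only a limit.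

Compound 4 `CSc1ccc(C2=C(c3ccc(Br)cc3)C(=O)N3CCCC3C2)cc1` has 4-bromophenyl in place of 4-fluoro-3-methylphenyl on a double-bonded ring carbon. Among the compounds with values here, no measured pair isolates this change, so the expectation rests on few data. In this assay, no step beyond the scatter is expected, and no direction is favoured. The expected step is a 1.2-fold higher number from compound 2 to compound 4 (0.08 log units; within the scatter). The estimate for compound 4 is 600 nM. The estimated range for compound 4 runs from 180 nM to 2500 nM.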

Compound 4, concentration for 50% growth inhibition: 8000 nM
Beside the measured number, compound 4's estimate is 13-fold (1.12 log units) below it; measured number outside the range, above it.
By their numbers in this assay, from the lowest: compounds 2 and 3 (each within the scatter of the next); then compound 4. At a limit, above all of these: compound 1.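

In this assay, the aryl group on the double-bonded ring carbon is not freely interchangeable: 4-bromophenyl in place of 4-fluoro-3-methylphenyl gives a 16-fold higher number from compound 2 to compound 4 (1.20 log units; beyond the scatter) with the rest of the structure unchanged. This is the only single-place comparison shown, and it places this position among those where one group change moves the number beyond the scatter. Nothing measured here gives a cause for the step. Going by these compounds, it remains open whether the fluorine, the methyl or the bromine carries the difference. Also open, on these data alone, is how an amine or a carboxylic acid on this aryl group would read in this assay.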